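A few compounds are considered here, and "the series" means these few. Any claim that something is new, unique, unknown or untested is made for them only; others in the source may bear on it.

In an ADME assay on Huh-7 cells (Homo sapiens) for cytotoxicity, read by MTT assay, with a stated time of 3 days (on this read-out higher numbers stand for lower toxicity in this test and lower numbers for higher toxicity in this test), two compounds sharing one core have been tested so far. Compound 1 `CCCCc1cn(-c2cccc(S(=O)(=O)Nc3ccccc3F)c2)nn1` gives > 200000 nM, which is a limit of the assay and not a number. Compound 2 `CCCCc1cn(-c2cccc(S(=O)(=O)Nc3cccc4cnccc34)c2)nn1` gives > 200000 nM, which is likewise only a limit. Compound 2 therefore has no exact position on this scale, and the evidence so far amounts to the limit of > 200000 nM in this assay, at which 2 of the 2 values shown sit.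

Compound 3 `CCOCc1cn(-c2cccc(S(=O)(=O)Nc3cccc4cnccc34)c2)nn1` keeps the core of compound 2 and alters only its side chain. The change is ethoxy in place of propyl on a saturated chain carbon bound to an aromatic carbon, or, cut one bond further out, butyl to ethoxymethyl. Among the compounds with values here, no measured pair shows what such a change does in this assay. The expectation therefore rests on compound 2 and its limit of > 200000 nM, and no step beyond the usual scatter is foreseen. The estimated step is a number no higher from compound 2 to compound 3 (the limit leaves the size open), and a further result reported only as a limit is expected. For compound 3 the expected value is 200000 nM, with an estimated range of 100000 nM to 400000 nM.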

Compound 3, half-maximal cytotoxic concentration: > 200000 nM
Compound 3: no number, only a limit; the forecaster's own chance of this, stated with the estimate: 85%; the middle value sits exactly at the limit.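

In this assay compound 3 gives > 200000 nM, which is a limit of the assay and not a number. Compound 2 also stands only at a limit, so no step can be read between compound 2 and compound 3. The compounds shown leave open whether ethoxy in place of propyl changes this read-out at all, since all that is known is this: the limit of > 200000 nM in this assay, at which 3 of the 3 values shown sit.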